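Benzamido for Phenoxy in a Kinase Inhibitor Series

The source may report more compounds than this note shows. Statements on the series, on what has been measured and on what is new or still open speak of the compounds shown alone.

Of the compounds shown here, three have so far been measured in an assay on isolated protein for inhibition of G protein-coupled receptor kinase 5 (Homo sapiens), read by TR-FRET, with stated times of 10 min and 1 h; on this read-out higher numbers stand for weaker inhibition and lower numbers for stronger inhibition. Compound 1 `CN(C)COc1cccc(-c2cnc(N)c(-c3nc4cccc(-c5ccccn5)c4o3)c2)c1` gives 5100 nM. Compound 2 `CCc1ccc2nc(-c3cc(-c4cnn(C5CCNCC5)c4)cnc3N)oc2c1O` gives 3400 nM in this assay. Compound 3 `Nc1ncc(-c2cnn(C3CCNCC3)c2)cc1-c1nc2ccc(Oc3ccccc3)cc2o1` gives 4000 nM in this assay, the second highest of the three numbers; its gap to compound 2 and its gap to compound 1 both lie within the scatter of repeated measurements, so the three compounds cannot be placed in any order on these data.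

Compound 4 `Nc1ncc(-c2cnn(C3CCNCC3)c2)cc1-c1nc2ccc(NC(=O)c3ccccc3)cc2o1` has not yet been measured. It differs from compound 3 in one place: benzamido in place of phenoxy on an aromatic carbon. Going by the values given here, no pair of measured compounds differs by this change alone, so there is no measured step of this kind to lean on, and the three measured numbers themselves give no trend to extend. Compound 4 is therefore expected to give 3200 nM in this assay, with a range from 1000 nM to 10000 nM. The step this estimate means, a 1.3-fold lower number from compound 3 to compound 4 (0.10 log units; within the scatter), is expected to remain within the scatter, in no clear direction.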

Compound 4, half-maximal inhibitory concentration: 3490 nM
The estimate for compound 4 lay 1.1-fold (0.04 log units) below the measured number; the measured number falls inside the stated range.
By their numbers in this assay, from the lowest: compounds 2, 4, 3 and 1 (each within the scatter of the next).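

Benzamido in place of phenoxy on this aromatic carbon, para to a fused ring and meta to a fused ring, gives a 1.1-fold lower number from compound 3 to compound 4 (0.06 log units; within the scatter) in this assay. Going by these compounds alone, this is the first step that can be read across a single change, and it shows that the exchange leaves no difference that can be told from the scatter. Benzamido has 9 heavy atoms where phenoxy has 7, and 1 hydrogen-bond donor where phenoxy has 0, yet these differences in the group do not appear in the read-out. Nothing measured here accounts for the two groups reading alike.

Open, on these data alone, is whether any group at this place would shift the number beyond the scatter, such as a small acetamido, a primary amine or a carboxylic acid. Also open, as far as these compounds go, is whether a substituent on the benzoyl ring of compound 4 would do so.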